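Swapping chloro for fluoro on a fused ring, second time

The source may report more compounds than this note shows. Statements on the series, on what has been measured and on what is new or still open speak of the compounds shown alone.

Compound 1 `Cc1cnc(Nc2ccc(S(C)(=O)=O)cc2)nc1Nc1nc2ccc(Cl)cc2s1` is the starting point. In a functional assay on MDA-MB-231 cells (Homo sapiens) for antiproliferative activity, read by MTT assay, with a stated time of 48 h (a higher number here means a weaker inhibitor, a lower number a stronger inhibitor), compound 1 gives 5900 nM. Compound 2 `Cc1cnc(Nc2ccc(S(C)(=O)=O)cc2)nc1Nc1nc2ccc(F)cc2s1` differs from it only in the change (fluoro in place of chloro on an aromatic carbon). In this assay compound 2 reaches only a limit of the assay, > 50000 nM; the evidence for this is the limit of > 50000 nM in this assay, at which 1 of the 3 values shown sits. That change brought an at least 8.4-fold higher number from compound 1 to compound 2 (0.92 log units; beyond the scatter). Compound 3 `CS(=O)(=O)c1ccc(Nc2ncc(F)c(Nc3nc4ccc(Cl)cc4s3)n2)cc1` carries a different core, described by fluoro in place of methyl on an aromatic carbon. In this assay compound 3 gives 11100 nM, a step of a 1.9-fold higher number from compound 1 to compound 3 (0.27 log units; within the scatter).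

Compound 4 `CS(=O)(=O)c1ccc(Nc2ncc(F)c(Nc3nc4ccc(F)cc4s3)n2)cc1` is not yet measured. It differs from compound 3 by fluoro in place of chloro on an aromatic carbon. The place of this change is the same, word for word, as the place of the change from compound 1 to compound 2, so it is the same change, now made on the core of compound 3. Because the same change gave an at least 8.4-fold higher number from compound 1 to compound 2 (0.92 log units; beyond the scatter), a step of similar size is expected here, estimated as an 8.1-fold higher number from compound 3 to compound 4 (0.91 log units; beyond the scatter). For compound 4 the expected value in this assay is therefore 90000 nM, most likely returned as a limit, within roughly 30000 nM to 300000 nM.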

Compound 4, half-maximal inhibitory concentration: 8900 nM
Estimate against measurement, compound 4: 10-fold (1.00 log units) above; the measured number lies below the stated range.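

In this assay the change from chloro to fluoro did not carry over from one core to the other, with a 1.2-fold lower number from compound 3 to compound 4 (0.10 log units; within the scatter) set against the large step on the core of compound 1, and the two steps differ: the same change on two cores in this assay, an at least 8.4-fold higher number (0.92 log units; beyond the scatter) from compound 1 to compound 2 and a 1.2-fold lower number (0.10 log units; within the scatter) from compound 3 to compound 4, at least 10-fold (1.02 log units) apart, beyond the scatter of two such steps
Read the other way round, the change from methyl to fluoro also gave different results in its two settings, with an at least 5.6-fold lower number from compound 2 to compound 4 (0.74 log units; beyond the scatter), so the outcome of each change depends on what else the molecule carries: the same change on two cores in this assay, a 1.9-fold higher number (0.27 log units; within the scatter) from compound 1 to compound 3 and an at least 5.6-fold lower number (0.74 log units; beyond the scatter) from compound 2 to compound 4, at least 10-fold (1.02 log units) apart, beyond the scatter of two such steps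
Compound 2 stands at > 50000 nM, a limit of the assay and not a number, and these pairs show neither the true size of its steps nor the reason the two cores behave differently.

With only two cores and two halogens shown, it stays open whether this dependence on the core holds for other pairs in the series. As far as these compounds go, it is also open how either core would respond if an amine, a methoxy group or a carboxylic acid took the place of the halogen.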